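The source may report more compounds than this note shows. Statements on the series, on what has been measured and on what is new or still open speak of the compounds shown alone.

Three compounds have so far been examined in a functional assay on MDA-MB-231 cells (Homo sapiens) for cytotoxicity, read by sulforhodamine B assay, with a stated time of 48 h, tested at 100 nM; on this read-out higher numbers stand for a weaker effect at the one concentration tested and lower numbers for a stronger effect. Compound 1 `COc1cc(C)cc(-c2nn(CC#N)cc2-c2ccc(-c3cccc(C(C)=O)c3)nc2)c1` gives 85%, compound 2 `Cc1cc(O)cc(-c2nn(CC#N)cc2-c2ccnc(-c3ccc(Oc4ccccc4)cc3)c2)c1` gives 85%, and compound 3 `COc1cc(C)cc(-c2nn(CC#N)cc2-c2ccnc(-c3ccc(N(C)C)cc3)c2)c1` gives 52%. Compound 3 thus stands lowest of the three, with compound 1 and compound 2 each higher by a margin beyond the usual scatter.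

Compound 4 `Cc1cc(O)cc(-c2nn(CC#N)cc2-c2ccnc(-c3ccc(N(C)C)cc3)c2)c1` has not yet been measured. It differs from compound 3 in one place: hydrogen in place of methyl on an oxygen on an aromatic ring. For the measured compounds named here, compound 2 also carries the 3-hydroxy-5-methylphenyl group and gives the higher 85%, but it differs from compound 3 elsewhere as well, so no single-change step is known. In this assay a small rise, possibly none beyond the scatter, is expected. Compound 4 is estimated at 62%, within 42% to 85%. This is expected to amount to a number 10 percentage points higher from compound 3 to compound 4 (within the scatter).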

Compound 4, a percentage reported as activity, at one concentration (the size of the read-out at that concentration, not a potency): 84%
Compound 4: middle estimate off by 22 percentage points, on the low side; low and high end bracket the measured number.
By their numbers in this assay, from the lowest: compound 3; then compounds 4, 1 and 2 (each within the scatter of the next).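

In this assay, methoxy to hydroxy on this oxygen proves a large change, giving a number 32 percentage points higher from compound 3 to compound 4 (beyond the scatter), so the methyl there matters with the dimethylamino group in place. With the hydroxy group held constant, dimethylamino in place of phenoxy gives a number 1 percentage points lower from compound 2 to compound 4 (within the scatter), a change that shows no effect beyond the scatter. Nothing available explains the step from methoxy to hydroxy.

On these data alone, whether an ethoxy group or a longer chain on that oxygen would keep the stronger effect of compound 3 stays open. Also open, as far as these compounds go, is whether an amine in place of that oxygen would do so.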